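The compounds below may be only part of what the source reports. "The series", "measured", "known", "first", "only" and "open" are said of these compounds alone.

Notes on the series. Compound 1 `C#CCOc1ccc(/C=C/C(=O)c2cccc(OC)c2)cc1OC` gives 1100 nM in a functional assay on ADR5000 cells for cytotoxicity against ADR5000 cell line (Homo sapiens), with a stated time of 72 h; a higher number here means a weaker inhibitor, a lower number a stronger inhibitor. Compound 2 `C#CCOc1ccc(/C=C/C(=O)c2cccc(C)c2)cc1OC` gives 1380 nM in this assay, and compound 3 `C=CCc1cc(C(C)=O)ccc1OCC=C(C)C` gives 5250 nM in this assay. Among the compounds with values here, the one measured step between compounds that differ in a single place is a 1.3-fold higher number from compound 1 to compound 2 (0.10 log units; within the scatter). Compound 2 thus holds the second highest of the three numbers, with compound 1 nearest and compound 3 furthest, the gap to compound 3 lying beyond the scatter.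

Compound 4 `C#CCOc1ccc(/C=C/C(=O)c2ccccc2C)cc1OC` is not yet measured. It differs from compound 2 in one place: 2-methylphenyl in place of 3-methylphenyl on a carbonyl carbon. Within the data shown here, no measured pair in the set moves a group from one place to another on the same ring. Among the measured compounds shown here, the only step measured on that ring, a 1.3-fold higher number from compound 1 to compound 2 (0.10 log units; within the scatter), exchanges one group for another and stays within the scatter, so it gives no direct guide to a change of position. With nothing in the set showing such a shift to matter, the step in this assay is expected to be small, a 1.2-fold higher number from compound 2 to compound 4 (0.06 log units; within the scatter), with no direction beyond the scatter. For compound 4 the estimate in this assay is 1600 nM, with a range from 800 nM to 3500 nM.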

Compound 4, half-maximal inhibitory concentration: 920 nM
Compound 4: the middle estimate sits 1.7-fold (0.24 log units) above what was measured; measured number inside the range.
By their numbers in this assay, from the lowest: compounds 4, 1 and 2 (each within the scatter of the next); then compound 3.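

In this assay, the ring on the carbonyl carbon now has a measured change of position: 2-methylphenyl in place of 3-methylphenyl gives a 1.5-fold lower number from compound 2 to compound 4 (0.18 log units; within the scatter), so this shift of the methyl group produces no step beyond the scatter. Exchanging 3-methoxyphenyl for 2-methylphenyl on the same carbonyl carbon, which changes both the group and its place, gives a 1.2-fold lower number from compound 1 to compound 4 (0.08 log units; within the scatter), so the three aryl ketone variants now measured all lie within the scatter of one another and none can be ranked above another. No measurement available here offers an explanation for these small steps.

From the compounds shown here alone, it remains open whether this position would respond to a group of a different kind, such as an amine or a carboxylic acid on the ring in place of the methyl group, since only methyl and methoxy appear there so far. Compound 3 differs from the other compounds in more than one place, so what separates its number from theirs cannot be assigned to any single structural change.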